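Replacing cyclohexyl with phenyl in a growth-inhibition test

This account rests on a few compounds, and the source may have more. Where it says the series, first, only, none or still open, it means among the compounds named here.

compound 1 `c1ccc(Oc2ccc(NC3=NCCO3)cc2)cc1`: 3500 nM
compound 2 `O=C(CCl)NC(=O)Nc1ccc(OC2CCCCC2)cc1`: 4700 nM

In a functional assay on MCF7 cells (Homo sapiens) for inhibition, read by sulforhodamine B assay, with a stated time of 48 h (on this read-out higher numbers stand for weaker inhibition of growth and lower numbers for stronger inhibition of growth), compound 2 and compound 1 lie within the usual scatter of each other, so neither can be ranked above the other. Compound 3 `O=C(CCl)NC(=O)Nc1ccc(Oc2ccccc2)cc1` differs from compound 2 in one place: phenyl in place of cyclohexyl on an oxygen on an aromatic ring. Going by the values given here, no measured pair shows this change directly. The phenoxy-bearing compound 1, at 3500 nM, offers only a loose guide, as its core differs. The estimated step of a 1.3-fold lower number from compound 2 to compound 3 (0.13 log units; within the scatter) is expected to stay within the scatter. For compound 3, the expected value is 3500 nM, with an estimated range of 1500 nM to 8000 nM.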

Compound 3, concentration for 50% growth inhibition: 4200 nM
Compound 3: middle estimate off by 1.2-fold (0.08 log units), on the low side, and the stated range covers the measured number.
By their numbers in this assay, from the lowest: compounds 1, 3 and 2 (each within the scatter of the next).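

In this assay phenyl in place of cyclohexyl on the oxygen gives a 1.1-fold lower number from compound 2 to compound 3 (0.05 log units; within the scatter) and so, at this position, the aromatic and non-aromatic six-membered rings cannot be told apart. With phenoxy kept, exchanging the group on the nitrogen on the aromatic ring gives a 1.2-fold higher number from compound 1 to compound 3 (0.08 log units; within the scatter) and so shows no readable difference there either. Nothing available explains these results. Still open, from the compounds shown here alone, is whether methyl or a longer chain such as hexyl, in place of phenyl on that oxygen, would give a number beyond the scatter.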